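A few compounds are considered here, and "the series" means these few. Any claim that something is new, unique, unknown or untested is made for them only; others in the source may bear on it.

Compound 1 `Cn1cc(-c2cnc3ccnc(N)c3c2)cn1` is the reference point of this short series. Among the measured compounds shown here, in a functional assay on A549 cells (Homo sapiens) for antiproliferative activity, read by MTT assay, with a stated time of 48 h (on this read-out lower numbers stand for stronger inhibition and higher numbers for weaker inhibition), compound 1 gives 33400 nM, and that is the only plain number so far. Compound 2 `Cn1cc(-c2cnc3ccc(NC(=O)c4ccc(F)cc4)nc3c2)cn1`, a related structure carrying an amide, is recorded in this assay only as > 50000 nM, a limit rather than a measured number. So (the limit of > 50000 nM in this assay, at which 1 of the 2 values shown sits), which leaves compound 1 as the sole anchor for what follows.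

Compound 3 `Cn1cc(-c2cnc3ccnc(NS(=O)(=O)c4cccs4)c3c2)cn1` differs from compound 1 in a single place: (thiophen-2-yl)sulfonyl in place of hydrogen on a nitrogen on an aromatic ring. For the measured compounds named here, no measured step of this kind exists here, so the expectation in this assay is for a step not larger than the usual scatter, in either direction. Compound 3 is therefore estimated at 25000 nM, with a likely range from 6000 nM to 60000 nM. That estimate means an expected step of a 1.3-fold lower number from compound 1 to compound 3 (0.13 log units; within the scatter).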

Compound 3, half-maximal inhibitory concentration: 9400 nM
The estimate for compound 3 lay 2.7-fold (0.42 log units) above the measured number, within the range that was stated.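

The nitrogen on the aromatic ring of compound 1 is a place where a change moves the number: in this assay, (thiophen-2-yl)sulfonyl in place of hydrogen gives a 3.6-fold lower number from compound 1 to compound 3 (0.55 log units; beyond the scatter). Among the compounds shown here, this is the first measured step, and it shows that this nitrogen can carry a much larger group than hydrogen without the activity being lost, although the gain is modest. Nothing measured here explains why the number falls.

A single pair cannot show whether the step comes from the sulfonyl link or from the thiophene ring. A methylsulfonyl or phenylsulfonyl group on the same nitrogen would help to separate the two, and an acetyl group would show whether a sulfonyl link is needed at all.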